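This account rests on a few compounds, and the source may have more. Where it says the series, first, only, none or still open, it means among the compounds named here.

Measured compounds:
Compound 1 `CC(=O)N(C)c1ccc(Nc2nccc(-c3ccccn3)n2)cc1`: 1800 nM
Compound 2 `CC(=O)Nc1ccc(Nc2nccc(-c3ccccn3)n2)cc1`: 1500 nM
Compound 3 `c1ccc(Nc2nccc(-c3ccncc3)n2)cc1`: 900 nM

In a functional assay for inhibition, with Homo sapiens as the target (on this read-out higher numbers stand for weaker inhibition and lower numbers for stronger inhibition), compound 3 gives 900 nM and compound 2 gives 1500 nM; the difference between the cores of compound 3 and compound 2 is not broken down here. Compound 1 differs from compound 2 by methyl in place of hydrogen on an amide-type nitrogen, which made a step of a 1.2-fold higher number from compound 2 to compound 1 (0.08 log units; within the scatter). Compound 4 `CN(c1ccccc1)c1nccc(-c2ccncc2)n1` differs from compound 3 by methyl in place of hydrogen on a nitrogen on an aromatic ring, the same kind of change but not the same one, since the place is here a nitrogen on an aromatic ring rather than an amide-type nitrogen. Going by the values given here, compound 4 is expected to show a step of a 1.8-fold higher number from compound 3 to compound 4 (0.25 log units; within the scatter) in this assay, somewhat larger than the earlier one, because the place differs and only the step of a 1.2-fold higher number from compound 2 to compound 1 (0.08 log units; within the scatter) is available to rest on. Compound 4 is therefore estimated at 1600 nM, between 600 nM and 4500 nM.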

Compound 4, half-maximal inhibitory concentration: > 24000 nM
Compound 4 was reported as a limit (the forecaster's own chance of this, stated with the estimate: 5%); middle value at least 15-fold (1.17 log units) from the limit.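

In this assay compound 4 gives > 24000 nM, which is a limit of the assay and not a number. Methyl in place of hydrogen did not carry from one core to the other as a step of one size: on a nitrogen on an aromatic ring it gave an at least 26-fold higher number from compound 3 to compound 4 (1.42 log units; beyond the scatter), and set against the earlier step on an amide-type nitrogen the two part clearly: the same change on two cores in this assay, a 1.2-fold higher number (0.08 log units; within the scatter) from compound 2 to compound 1 and an at least 26-fold higher number (1.42 log units; beyond the scatter) from compound 3 to compound 4, at least 22-fold (1.34 log units) apart, beyond the scatter of two such steps This does not show the true size of the step to compound 4, and it does not separate the core from the place, for the two pairs differ in both.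

Left open is what methyl on the nitrogen on an aromatic ring would do in the core of compound 2. Also open, on these data alone, is whether an ethyl group or a longer chain on that nitrogen in compound 4 would read any differently.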